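The compounds below may be only part of what the source reports. "The series", "measured", "known", "first", "only" and "open" are said of these compounds alone.

Compound 1 `CCC/C=C\C(=O)Nc1cc(Nc2nccc(-c3cn(C)c4ccccc34)n2)c(OC)cc1N(C)CCN(C)C` in a functional assay on HepG2 cells (Homo sapiens) for antiproliferative activity, read by MTT assay, with a stated time of 72 h (a higher number here means a weaker inhibitor, a lower number a stronger inhibitor), gives 431 nM.
Compound 2 `C=C(Cl)C(=O)Nc1cc(Nc2ncc(C#N)c(-c3cn(C)c4ccccc34)n2)c(OC)cc1N(C)CCN(C)C` gives 115 nM.
Compound 3 `CC/C=C\C(=O)Nc1cc(Nc2ncc(C#N)c(-c3cn(C)c4ccccc34)n2)c(OC)cc1N(C)CCN(C)C` gives 1360 nM.

Among these three, compound 3 has the highest number; its nearest neighbour is compound 1, and compound 2 lies furthest away, separated by the step of a 12-fold higher number from compound 2 to compound 3 (1.07 log units; beyond the scatter). Compound 4 `CCC/C=C\C(=O)Nc1cc(Nc2ncc(C#N)c(-c3cn(C)c4ccccc34)n2)c(OC)cc1N(C)CCN(C)C` differs from compound 3 by methyl in place of hydrogen on a saturated chain carbon, two bonds along the chain from a double-bonded chain carbon. Going by the values given here, no measured pair shows exactly this change. Among the compounds with values here, the only single-place step, a 12-fold higher number from compound 2 to compound 3 (1.07 log units; beyond the scatter), concerns a different replacement on the carbonyl carbon and so gives little guidance. Compound 1 also bears the pent-1-en-1-yl chain, though its core differs elsewhere, and gives 431 nM, a lower number than compound 3. A modest decrease, a 1.9-fold lower number from compound 3 to compound 4 (0.29 log units; within the scatter), is therefore expected. For compound 4 the estimated value is 700 nM, with a range from 300 nM to 1800 nM.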

Compound 4, half-maximal inhibitory concentration: 1690 nM
Estimate against measurement, compound 4: 2.4-fold (0.38 log units) below; the measured number falls inside the stated range.
By their numbers in this assay, from the lowest: compound 2; then compound 1; then compounds 3 and 4 (each within the scatter of the next).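

In this assay at this saturated chain carbon, methyl in place of hydrogen gives a 1.2-fold higher number from compound 3 to compound 4 (0.09 log units; within the scatter) and so but-1-en-1-yl and pent-1-en-1-yl cannot be told apart. Pent-1-en-1-yl in place of 1-chloroethenyl gives a 15-fold higher number from compound 2 to compound 4 (1.17 log units; beyond the scatter) as a large step, much like the one seen with but-1-en-1-yl. Going by these compounds alone, with pent-1-en-1-yl held fixed, cyano in place of hydrogen on an aromatic carbon gives a 3.9-fold higher number from compound 1 to compound 4 (0.59 log units; beyond the scatter) and this is the first reading of that change alone.

As far as these compounds go, whether a longer chain or an amine on the chain would shift the number remains open. No measurement shown gives a cause for any of these steps.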